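Next group on the ring nitrogen: compound 3

A few compounds are considered here, and "the series" means these few. Any claim that something is new, unique, unknown or untested is made for them only; others in the source may bear on it.

Measured in a functional assay on A549 cells (Homo sapiens) for antiproliferative activity, read by MTT assay, with a stated time of 48 h; on this read-out lower numbers stand for stronger inhibition and higher numbers for weaker inhibition:
- compound 1 `O=C(/C=C/c1ccc(O)c(O)c1)N1CCN(c2ccccc2F)CC1`: 1.43 ug/mL
- compound 2 `COc1ccc(N2CCN(C(=O)/C=C/c3ccc(O)c(O)c3)CC2)cc1`: 0.93 ug/mL

Compound 2, at 0.93 ug/mL, has only compound 1 for comparison, and the two values lie within the scatter of each other. The next compound, compound 3 `Cc1ccc(N2CCN(C(=O)/C=C/c3ccc(O)c(O)c3)CC2)c(C)c1`, keeps the shared core and carries 2,4-dimethylphenyl in place of 4-methoxyphenyl on an amine nitrogen in a ring. The counted difference is 2,4-dimethylphenyl in place of 4-methoxyphenyl on an amine nitrogen in a ring.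

Among the compounds with values here, one measured step bears on this change. That step, a 1.5-fold lower number from compound 1 to compound 2 (0.19 log units; within the scatter), also exchanged the group at this place and stayed within the scatter. Within the data shown here, no measured compound carries 2,4-dimethylphenyl, and a single step is a thin basis, so no direction can be argued from the data. No shift beyond the scatter is expected in this assay, and the estimate stays close to the two measured values. The expected change is a 1.2-fold higher number from compound 2 to compound 3 (0.07 log units; within the scatter), which is no real move. For compound 3 the estimated value is 1.1 ug/mL, with an expected range from 0.45 ug/mL to 2.7 ug/mL.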

Compound 3, half-maximal inhibitory concentration: 1.02 ug/mL
For compound 3 the middle estimate is 1.1-fold (0.03 log units) above the measured one; the measured number falls inside the stated range.
By their numbers in this assay, from the lowest: compounds 2, 3 and 1 (each within the scatter of the next).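

In this assay, within the data shown here, the exchange of 4-methoxyphenyl for 2,4-dimethylphenyl on the amine nitrogen in the ring gives a 1.1-fold higher number from compound 2 to compound 3 (0.04 log units; within the scatter), even though the entering group has no counterpart to the oxygen and the hydrogen-bond acceptor counted on the leaving group. With a 1.4-fold lower number from compound 1 to compound 3 (0.15 log units; within the scatter) also printed as within the scatter, all three pairs at this place now lie within the scatter, so 2-fluorophenyl, 4-methoxyphenyl and 2,4-dimethylphenyl cannot be told apart in this read-out, a statement that holds for these compounds only. No supporting measurement is available to account for this flat picture.

The compounds shown leave open whether the same flat picture would hold for a group of another kind on this nitrogen, such as cyclohexyl, benzyl or a phenyl ring carrying a carboxylic acid, since every group seen so far is a six-membered aromatic ring of carbon only. From the compounds shown here alone, the shared core stays fixed throughout, so the contribution of its other parts, including the two hydroxyl groups, also remains open.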